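A few compounds are considered here, and "the series" means these few. Any claim that something is new, unique, unknown or untested is made for them only; others in the source may bear on it.

Three acrylamide-bearing thiazepinones have been run in a functional assay on MOLT-4 cells (Homo sapiens) for cytotoxicity, read by CCK-8 assay, with a stated time of 24 h; a lower number here means a stronger inhibitor, a higher number a weaker inhibitor. Compound 1 `C=CC(=O)N1C(=O)CC(c2cccc(Cl)c2)Sc2ccccc21` gives 77500 nM; compound 2 `C=CC(=O)N1C(=O)CC(c2ccc(C(F)(F)F)cc2)Sc2ccccc21` gives 76300 nM; compound 3 `C=CC(=O)N1C(=O)CC(c2ccccc2Cl)Sc2ccccc21` gives 80300 nM. Compound 1 falls within the scatter of both compound 2 and compound 3, so the three numbers cannot be told apart. Among the measured compounds shown here, the only single-point step, a 1.0-fold higher number from compound 1 to compound 3 (0.02 log units; within the scatter), shows that moving the chlorine around the phenyl ring changes nothing measurable.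

Compound 4 `C=CC(=O)N1C(=O)CCSc2ccccc21` differs from compound 1 by hydrogen in place of 3-chlorophenyl on a saturated ring carbon. For the measured compounds named here, no measured step removes the aryl group outright, so the measured steps give no direct guide; the expectation rests only on the shared core. A step of a 1.5-fold higher number from compound 1 to compound 4 (0.19 log units; within the scatter) toward a higher number is expected. Compound 4 is estimated at 120000 nM, range 50000 nM to 300000 nM.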

Compound 4, half-maximal inhibitory concentration: 565000 nM
For compound 4 the middle estimate is 4.7-fold (0.67 log units) below the measured one, outside the stated range (above it).
By their numbers in this assay, from the lowest: compounds 2, 1 and 3 (each within the scatter of the next); then compound 4.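

Unlike moving the chlorine around the phenyl ring, removing the aryl group from the saturated ring carbon next to the ring sulfur registers in this assay: hydrogen in place of 3-chlorophenyl gives a 7.3-fold higher number from compound 1 to compound 4 (0.86 log units; beyond the scatter) and hydrogen in place of 2-chlorophenyl gives a 7.0-fold higher number from compound 3 to compound 4 (0.85 log units; beyond the scatter) as a matching result. An aryl group at this carbon therefore counts, while the place of its chlorine does not, though both steps remain modest. No measured evidence explains this difference.

As far as these compounds go, whether an aryl ring is needed here remains open, since a cyclohexyl ring, a short alkyl chain or an amine at this carbon could separate the ring from mere bulk. From the compounds shown here alone, a carboxylic acid on the phenyl ring also remains untested in these compounds.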